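Amino in Place of Hydroxy: Expecting Little in Paw Edema

The compounds below may be only part of what the source reports. "The series", "measured", "known", "first", "only" and "open" are said of these compounds alone.

compound 1 `C/C(=N\OCC(=O)O)c1ccccc1` — < 20%
compound 2 `CC(=O)Nc1ccc(/C(C)=N/OCC(=O)O)cc1` — < 20%

In a functional assay on the whole organism for inhibition, with Rattus norvegicus as the target, read by paw edema, with stated times of 1 h and 3 h, at a dose of 50 mg/kg by the oral route (a higher number here means more inhibition at the dose given (going by the name of the read-out), a lower number less inhibition), compound 1 returns a limit of the assay rather than a number. Compound 2 likewise sits at a limit in this assay. Among the compounds with values here, the only measured step, a step that the two limits leave unreadable from compound 1 to compound 2, is therefore unreadable in size, and this is so because of the limit of < 20% in this assay, at which 2 of the 2 values shown sit; both values rest at the same floor.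

Compound 3 `C/C(=N\OCC(N)=O)c1ccccc1` differs from compound 1 by amino in place of hydroxy on a carbonyl carbon. Within the data shown here, no measured step concerns this change; the single step on record alters an aromatic carbon, not the carbonyl carbon, so it offers no guidance on size or direction for compound 3. With compound 1 at a limit, an upward move is possible but unsupported, and the expectation is that compound 3 stays close to where compound 1 stands. The step that the limit leaves unreadable from compound 1 to compound 3 is expected to be small, within the scatter. Compound 3 is thus estimated at 15%, in the range from 0% to 35%, with a fair chance that this assay again reports only a limit.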

Compound 3, a percentage reported as inhibition, in the whole organism at one dose (the size of the read-out at that dose, not a potency): < 20%
Compound 3: no number, only a limit (the forecaster's own chance of this, stated with the estimate: 60%); the middle value is on the limit's open side.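

In this assay compound 3 gives < 20%, a limit of the assay and not a number. No size can be read for the change from compound 1 to compound 3, because both sit at the same limit: the limit of < 20% in this assay, at which 3 of the 3 values shown sit. The compounds shown leave open whether carboxy and carbamoyl differ at all in this read-out.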